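Replacing a Chain Hydroxy Group in a Curcumin-like Enaminone

This account rests on a few compounds, and the source may have more. Where it says the series, first, only, none or still open, it means among the compounds named here.

Measured compounds:
- compound 1, `COc1cc(/C=C/C(=O)/C=C(/C=C/c2ccc(O)c(OC)c2)NCCO)ccc1O`: 90.9%
- compound 2, `COCCCNC(=C\C(=O)/C=C/c1ccc(O)cc1)/C=C/c1ccc(O)cc1`: 97%

Two related compounds have been tested in an ADME assay on CHO-K1 cells (Cricetulus griseus) for activation, read by fluorescence, tested at 10 uM; on this read-out lower numbers stand for a stronger effect and higher numbers for a weaker effect at the one concentration tested. In this assay compound 1 gives 90.9%, and compound 2 gives 97%. The two numbers lie within the usual scatter of each other, so neither compound can be called stronger or weaker; both sit near the top of the scale, where the effect at the tested concentration is small.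

Compound 3, `COCCCNC(=C\C(=O)/C=C/c1ccc(O)c(OC)c1)/C=C/c1ccc(O)c(OC)c1`, has not been measured yet. It differs from compound 1 in one place: methoxymethyl in place of hydroxy on a saturated chain carbon, two bonds along the chain from an amine nitrogen. Among the compounds with values here, no measured pair in this set shows this particular change on its own, so its effect can only be guessed. Because compound 1 gives 90.9% and compound 2, which already carries the longer chain, gives 97%, compound 3 is expected to stay in the same weak region, with a step of about a number 3.1 percentage points higher from compound 1 to compound 3 (within the scatter), not beyond the scatter. Compound 3 is therefore estimated at 94%, within a range from 82% to 104%.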

Compound 3, a percentage reported as activity, at one concentration (the size of the read-out at that concentration, not a potency): 81.2%
For compound 3 the middle estimate is 12.8 percentage points above the measured one; measured number below the stated range.
By their numbers in this assay, from the lowest: compounds 3, 1 and 2 (each within the scatter of the next, the first and the last beyond it).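

Within the data shown here, compound 3 gives the first direct reading of this change. In this assay, the change gives a number 9.7 percentage points lower from compound 1 to compound 3 (within the scatter) for this single pair. The exchange removes a hydroxy with 1 hydrogen-bond donor and brings in a methoxymethyl with 0 hydrogen-bond donors and a larger count of heavy atoms, yet the step stays within the scatter, so this pair offers no sign that the read-out depends on that donor, and no evidence here explains the size of the step.

Going by these compounds, a single pair cannot show how far this tolerance reaches, so it remains open whether an amine or a carboxylic acid at the end of the chain would also stay within the scatter, and whether a longer chain would do the same. Because the read-out comes from one concentration, it also leaves open how compound 1 and compound 3 would compare across a range of concentrations.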